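Swapping a carbamate-bearing chain for a pyrrolidine ring

A few compounds are considered here, and "the series" means these few. Any claim that something is new, unique, unknown or untested is made for them only; others in the source may bear on it.

Compound 1, with structure `Cn1cncc1CN1CC(N(CC2CCN(C(=O)CNC(=O)OC(C)(C)C)CC2)S(=O)(=O)c2ccccn2)Cc2cc(C#N)ccc21`, is one of three related compounds whose passage across a cell layer has been measured. In an ADME assay on Caco-2 cells (Homo sapiens) for permeability, in the apical to basolateral direction (a lower number here means that the compound crosses the layer more slowly, a higher number that the compound crosses the layer faster), compound 1 gives 0.5 10^-6 cm/s. This places compound 1 second highest of the three numbers. Its nearest neighbour is compound 3, `Cn1cncc1CN1CC(N(CC2CCN(C(=O)NC(C)(C)C)CC2)S(=O)(=O)c2ccccn2)Cc2cc(C#N)ccc21`, which in this assay gives 0.6 10^-6 cm/s, a difference described by a 1.2-fold higher number from compound 1 to compound 3 (0.08 log units; within the scatter). The furthest is compound 2, `Cn1cncc1CN1CC(N(CC2CCN(S(C)(=O)=O)CC2)S(=O)(=O)c2ccccn2)Cc2cc(C#N)ccc21`, which gives 0.1 10^-6 cm/s, the step being a 5.0-fold lower number from compound 1 to compound 2 (0.70 log units; beyond the scatter).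

Compound 4, `Cn1cncc1CN1CC(N(CC2CCN(C(=O)N3CCCC3)CC2)S(=O)(=O)c2ccccn2)Cc2cc(C#N)ccc21`, has not yet been measured. Its difference from compound 1 is pyrrolidin-1-yl in place of ((tert-butoxycarbonyl)amino)methyl on a carbonyl carbon. Cut one bond further out, the change reads (((tert-butoxycarbonyl)amino)methyl)carbonyl to (pyrrolidin-1-yl)carbonyl, so the carbonyl on the ring nitrogen is kept.

Among the measured compounds shown here, two measured steps bear on this. The step of a 1.2-fold higher number from compound 1 to compound 3 (0.08 log units; within the scatter) shows that exchanging what sits on that carbonyl carbon for a different nitrogen-based group left the number within the scatter. The step of a 6.0-fold higher number from compound 2 to compound 3 (0.78 log units; beyond the scatter) shows that keeping a carbonyl rather than a methylsulfonyl on the ring nitrogen matters more. Since compound 4 keeps the carbonyl, the expected step is small, a 2.0-fold higher number from compound 1 to compound 4 (0.30 log units; within the scatter), with perhaps a slight rise. Compound 4 is therefore estimated at 1 10^-6 cm/s, within a range from 0.4 10^-6 cm/s to 2.5 10^-6 cm/s.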

Compound 4, apparent permeability: 0.6 10^-6 cm/s
The estimate for compound 4 lay 1.7-fold (0.22 log units) above the measured number, and the stated range covers the measured number.
By their numbers in this assay, from the lowest: compound 2; then compounds 1, 3 and 4 (each within the scatter of the next).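

Pyrrolidin-1-yl puts a ring on this carbonyl carbon for the first time among these compounds, yet exchanging ((tert-butoxycarbonyl)amino)methyl, with 9 heavy atoms and 1 hydrogen-bond donor, for this group with 5 heavy atoms and 0 donors leaves the number within the scatter (a 1.2-fold higher number from compound 1 to compound 4 (0.08 log units; within the scatter)). The ring also cannot be told apart from the open (tert-butyl)amino group (no change at the digits printed from compound 3 to compound 4 (within the scatter)), so all three groups so far placed on this carbon give numbers within the scatter of one another. Among the compounds shown here, the gap to the methylsulfonyl compound is as large as the one seen for compound 3 (a 6.0-fold higher number from compound 2 to compound 4 (0.78 log units; beyond the scatter)), which leaves the exchange of carbonyl for methylsulfonyl on the amine nitrogen in a ring as the only step beyond the scatter, with compound 2 the lone compound on the low side.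

No measurement at hand explains why these numbers fall as they do. From the compounds shown here alone, it also remains open whether an amine, a carboxylic acid or a longer chain on this carbonyl carbon would stay with compounds 1, 3 and 4 or move away from them.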